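Series notes: isobutyl to neopentyl on compound 3

The source may hold more compounds than are shown below. What is called first, only, known or untested is meant among the compounds shown, and "the series" means these compounds.

Measured so far:
compound 1, `Cc1ccc(NC(=O)CC(CCN)c2nnc(CCCC(C)C)n2C2CC2)c(C)c1`, 88%
compound 2, `CNC(=O)CCC(CC(=O)Nc1ccc(C)cc1C)c1nnc(CCCC(C)C)n1C1CC1`, 65%
compound 3, `Cc1ccc(NC(=O)C[C@H](CCC(=O)O)c2noc(-c3cc(CC(C)C)on3)c2C2CC2)c(Cl)c1`, 74%

In an ADME assay on microsomes from liver (Homo sapiens) for metabolic stability, with a stated time of 60 min (a higher number here means that more of the compound is left, a lower number that less of the compound is left), compound 3 stands second highest of the three numbers. Its nearest neighbour is compound 2, which gives 65%, a gap within the scatter; the furthest is compound 1, which gives 88%, a gap beyond the scatter.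

Compound 4, `Cc1ccc(NC(=O)C[C@H](CCC(=O)O)c2noc(-c3cc(CC(C)(C)C)on3)c2C2CC2)c(Cl)c1`, differs from compound 3 by a single change: methyl in place of hydrogen on a saturated chain carbon bound to three saturated chain carbons.

Among the compounds with values here, the one measured step, a number 23 percentage points lower from compound 1 to compound 2 (beyond the scatter), concerns a different change and does not bear on the step from compound 3 to compound 4. Within the data shown here, no measured pair shows the effect of methyl in place of hydrogen on a saturated chain carbon bound to three saturated chain carbons. With nothing to anchor a shift in either direction, the expectation for this assay is a step no larger than the scatter, in no particular direction.

Compound 4 is therefore estimated at 74%, with a range of 58% to 90%, which means an expected step of no change at the digits printed from compound 3 to compound 4 (within the scatter).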

Compound 4, percent of the compound remaining: 84%
For compound 4 the middle estimate is 10 percentage points below the measured one; the range from low to high includes it.
By their numbers in this assay, from the lowest: compounds 2, 3, 4 and 1 (each within the scatter of the next, the first and the last beyond it).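

In this assay, within the data shown here, the change from isobutyl to neopentyl, methyl in place of hydrogen on a saturated chain carbon bound to three saturated chain carbons, gives a number 10 percentage points higher from compound 3 to compound 4 (within the scatter) and is the only reading so far at this position. This one pair shows that the position accepts the added methyl with the percent remaining still within the scatter of compound 3, so neither a gain nor a loss can be claimed from it. Nothing measured here gives a reason for this outcome.

Open, on these data alone, is how the position responds to groups of another kind, such as an ether, a primary alcohol or a longer chain in place of neopentyl. Also open, as far as these compounds go, is whether the same methyl change reads alike with other groups elsewhere on the shared core.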